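This account rests on a few compounds, and the source may have more. Where it says the series, first, only, none or still open, it means among the compounds named here.

Within the data shown here, in a functional assay on Shh Light II cells (Mus musculus) for inhibition, read by a luciferase reporter (a lower number here means a stronger inhibitor, a higher number a weaker inhibitor), compound 3 `N#Cc1ccccc1NC(=O)N1CCC(c2nc(-c3ccc4ccccc4n3)no2)CC1` gives 190 nM, the lowest number so far, against compound 1 `O=C(Nc1ccccc1Cl)N1CCC(c2nc(-c3ccc4ccccc4n3)no2)CC1` at 510 nM and compound 2 `O=C(OC1CCCCC1)N1CCC(c2nc(-c3ccc4ccccc4n3)no2)CC1` at 580 nM. Compound 4 `COc1ccccc1OC(=O)N1CCC(c2nc(-c3ccc4ccccc4n3)no2)CC1` is unmeasured and has 2-methoxyphenoxy in place of (2-cyanophenyl)amino on a carbonyl carbon.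

The closest evidence is a 3.1-fold lower number from compound 2 to compound 3 (0.48 log units; beyond the scatter), a modest change at the same carbonyl carbon. Also relevant are a 2.7-fold lower number from compound 1 to compound 3 (0.43 log units; beyond the scatter), likewise modest, and a 1.1-fold higher number from compound 1 to compound 2 (0.06 log units; within the scatter), which stays within the scatter. Among the measured compounds shown here, no measured compound carries 2-methoxyphenoxy, so this is a loose read-across. A modest step to a higher number is expected in this assay. The expected step is a 2.4-fold higher number from compound 3 to compound 4 (0.37 log units; beyond the scatter). The estimate for compound 4 is 450 nM, with an expected range of 170 nM to 1200 nM.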

Compound 4, half-maximal inhibitory concentration: 250 nM
Compound 4: middle estimate off by 1.8-fold (0.26 log units), on the high side; the measured number falls inside the stated range.
By their numbers in this assay, from the lowest: compounds 3 and 4 (each within the scatter of the next); then compounds 1 and 2 (each within the scatter of the next).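

In this assay the carbonyl carbon accepts an oxygen link as readily as a nitrogen link when an aryl group is attached, with a 1.3-fold higher number from compound 3 to compound 4 (0.12 log units; within the scatter) despite the loss of the hydrogen-bond donor of (2-cyanophenyl)amino. Swapping cyclohexyl for 2-methoxyphenyl on the same oxygen gives a 2.3-fold lower number from compound 2 to compound 4 (0.37 log units; beyond the scatter), so the oxygen link alone does not set the number, and a 2.0-fold lower number from compound 1 to compound 4 (0.31 log units; beyond the scatter) shows that a donor is not needed to improve on compound 1. No available evidence explains these steps.

Still open, from the compounds shown here alone, is whether the methoxy group matters, as an unsubstituted phenoxy would show. A carboxylic acid or an amine in its place is equally untested here.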